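This account rests on a few compounds, and the source may have more. Where it says the series, first, only, none or still open, it means among the compounds named here.

In a functional assay on NIH3T3 cells (Mus musculus) (a higher number here means that more compound is needed for the effect, a lower number that less compound is needed), compound 1 (`Cn1cncc1C(OCc1ccc(C#N)cc1C#Cc1ccc(C#N)cc1)c1ccc(C#N)cc1`) gives 11.6 nM and compound 2 (`Cn1cncc1C(OCc1ccc(C#N)cc1/C=C/c1ccccn1)c1ccc(C#N)cc1`) gives 23.1 nM, so compound 2 stands within the scatter of compound 1. Compound 3 (`Cn1cncc1C(OCc1ccc(C#N)cc1C#Cc1ccc([N+](=O)[O-])cc1)c1ccc(C#N)cc1`) differs from compound 2 on an aromatic carbon: 2-(4-nitrophenyl)ethynyl in place of 2-(pyridin-2-yl)ethenyl on an aromatic carbon. Among the measured compounds shown here, one measured step bears on this change, a 2.0-fold higher number from compound 1 to compound 2 (0.30 log units; within the scatter), and it replaces a group at the same carbon without leaving the scatter. No shift beyond the scatter is therefore expected in this assay, and the expected step is a 1.5-fold lower number from compound 2 to compound 3 (0.19 log units; within the scatter). For compound 3 the estimated value is 15 nM, with an expected range of 6 nM to 40 nM.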

Compound 3, half-maximal effective concentration: 36 nM
Compound 3: the middle estimate sits 2.4-fold (0.38 log units) below what was measured; low and high end bracket the measured number.
By their numbers in this assay, from the lowest: compounds 1, 2 and 3 (each within the scatter of the next, the first and the last beyond it).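

In this assay, replacing the whole group on this aromatic carbon with 2-(4-nitrophenyl)ethynyl changes little (a 1.6-fold higher number from compound 2 to compound 3 (0.19 log units; within the scatter)). Among the compounds shown here, with the ethynyl kept, nitro in place of cyano on the terminal ring gives the only step here beyond the scatter, though a modest one (a 3.1-fold higher number from compound 1 to compound 3 (0.49 log units; beyond the scatter)). Nothing available explains this step. Because compound 2 differs from the other two in both linker and ring, the contributions of ethenyl and pyridin-2-yl remain unseparated. Also open, going by these compounds, is how an amine or a carboxylic acid in place of nitrile or nitro on the terminal ring would read out.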